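This account rests on a few compounds, and the source may have more. Where it says the series, first, only, none or still open, it means among the compounds named here.

Compound 1 `C#CCN(CCC)Cc1cn(-c2cc(NC(=S)NCC)ncn2)cn1`: 24.3%
Compound 2 `C#CCN(CCCC)Cc1cn(-c2cc(NC(=S)NCC)ncn2)cn1`: 20.1%
Compound 3 `C#CCN1CCN(Cc2cn(-c3cc(NC(=S)NCC)ncn3)cn2)CC1`: 13.3%

In an assay on isolated protein for inhibition of Amine oxidase [flavin-containing] B (Homo sapiens), read by fluorescence and Amplex Red, with a stated time of 15 min, tested at 50 uM (on this read-out lower numbers stand for less inhibition and higher numbers for more inhibition at the one concentration tested (going by the name of the read-out)), compound 3 stands lowest of the three, yet only its gap to compound 1 lies beyond the scatter. Compound 4 `C#CCNCCCc1cn(-c2cc(NC(=S)NCC)ncn2)cn1` differs from it by 2-(propargylamino)ethyl in place of 4-propargylpiperazin-1-yl on a saturated chain carbon bound to an aromatic carbon. Going by the values given here, two measured steps bear on this exchange at the same place: a number 11 percentage points lower from compound 1 to compound 3 (beyond the scatter), and a number 6.8 percentage points lower from compound 2 to compound 3 (within the scatter). Both led into the ring-bearing compound 3 from partners carrying an open chain, and the change to compound 4 again gives up the ring for a chain. A modest upward step is therefore expected, a number 8.7 percentage points higher from compound 3 to compound 4 (within the scatter), though it may well fall within the scatter. Compound 4 is expected to give 22% in this assay, with a range from 10% to 35%.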

Compound 4, a percentage reported as inhibition, at one concentration (the size of the read-out at that concentration, not a potency): 36.6%
The estimate for compound 4 lay 14.6 percentage points below the measured number, outside the stated range (above it).
By their numbers in this assay, from the lowest: compounds 3, 2 and 1 (each within the scatter of the next, the first and the last beyond it); then compound 4.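

At this saturated chain carbon bound to an aromatic carbon, 2-(propargylamino)ethyl in this assay gives a number 23.3 percentage points higher from compound 3 to compound 4 (beyond the scatter), and it also surpasses the open chains, with a number 16.5 percentage points higher from compound 2 to compound 4 (beyond the scatter) and a number 12.3 percentage points higher from compound 1 to compound 4 (beyond the scatter). Losing the ring therefore does not set the level on its own, since compound 1 and compound 2 carry open chains too, while compound 4, with the smallest group, gives the highest number of the four. Nothing at hand explains this gain.

On these data alone, it remains open whether the hydrogen on the propargylamine nitrogen matters, as a methyl group there would test. As far as these compounds go, how a chain shorter or longer than the ethyl one would read also remains open.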